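The source may report more compounds than this note shows. Statements on the series, on what has been measured and on what is new or still open speak of the compounds shown alone.

In a toxicity assay on cells (Erythrocyte, Mus musculus) for activation, read by spectrophotometry and hemolysis, with a stated time of 30 min (a higher number here means that more compound is needed for the effect, a lower number that less compound is needed), compound 1 `CN(C)c1ccc(/C=N/Nc2nc3ccccc3s2)cc1` gives > 200 ug/mL as its reading, which is a limit of the assay and not a number. Compound 2 `COc1ccc(/C=N/Nc2nc3ccccc3s2)c(OC)c1` gives > 200 ug/mL as its reading, again a limit and not a number. For the measured compounds named here, the measured set therefore consists of the limit of > 200 ug/mL in this assay, at which 2 of the 2 values shown sit, and offers no measured step between compounds. Compound 3 `C(=N/Nc1nc2ccccc2s1)\c1ccc(-c2ccccn2)cc1` carries pyridin-2-yl in place of dimethylamino on an aromatic carbon of the core of compound 1, and the change counts as pyridin-2-yl in place of dimethylamino on an aromatic carbon with the rest of the structure kept. In this assay the expected step of a number no higher from compound 1 to compound 3 (the limit leaves the size open) is estimated to stay within the usual scatter, with no direction favoured. That expectation rests only on compound 1 and its limit of > 200 ug/mL as the anchor. Compound 3 is expected at 200 ug/mL with an estimated range from 80 ug/mL to 400 ug/mL and may well come out only as a limit.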

Compound 3, half-maximal effective concentration: > 200 ug/mL
Compound 3: a limit, no number (the forecaster's own chance of this, stated with the estimate: 75%); the middle value lies on the limit itself.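

For the compounds shown here, compound 1 and compound 3 both stand as limits in this assay and no step between them can be read. The compounds shown leave open at what concentration any of them gives the effect, and whether pyridin-2-yl in place of dimethylamino alters that concentration.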